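From ethyl to 3-aminophenyl on the shared core

This account rests on a few compounds, and the source may have more. Where it says the series, first, only, none or still open, it means among the compounds named here.

Compound 1 `CC(Nc1ccccc1Oc1cccc(F)c1)=C1C(=O)CC(c2ccccc2)CC1=O`: 170 nM
Compound 2 `CC(=O)c1ccc(Oc2ccccc2NC(C)=C2C(=O)CC(c3ccccc3)CC2=O)cc1`: 220 nM
Compound 3 `CCOc1ccccc1NC(C)=C1C(=O)CC(c2ccccc2)CC1=O`: 190 nM

In a functional assay on CCRF-CEM cells (Homo sapiens) for antiproliferative activity, read by cell counting, with a stated time of 96 h (a lower number here means a stronger inhibitor, a higher number a weaker inhibitor), compound 3 cannot be separated from the other two compounds. Compound 4 `CC(Nc1ccccc1Oc1cccc(N)c1)=C1C(=O)CC(c2ccccc2)CC1=O` has 3-aminophenyl in place of ethyl on an oxygen on an aromatic ring. Two measured steps exchange ethyl with another group at that place: a 1.1-fold higher number from compound 1 to compound 3 (0.05 log units; within the scatter), and a 1.2-fold lower number from compound 2 to compound 3 (0.06 log units; within the scatter). The exchange between the two ring-bearing groups is also small: a 1.3-fold higher number from compound 1 to compound 2 (0.11 log units; within the scatter). No step beyond the scatter is therefore expected in this assay, although 3-aminophenyl itself is still unmeasured here. The expected step is a 1.1-fold higher number from compound 3 to compound 4 (0.02 log units; within the scatter). For compound 4, the estimate is 200 nM, with an expected range of 90 nM to 440 nM.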

Compound 4, half-maximal inhibitory concentration: 42 nM
Beside the measured number, compound 4's estimate is 4.8-fold (0.68 log units) above it; measured number outside the range, below it.
By their numbers in this assay, from the lowest: compound 4; then compounds 1, 3 and 2 (each within the scatter of the next).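

In this assay, the group on this oxygen had seemed not to matter, but 3-aminophenyl stands apart from all three earlier groups: a 4.5-fold lower number from compound 3 to compound 4 (0.66 log units; beyond the scatter), a 5.2-fold lower number from compound 2 to compound 4 (0.72 log units; beyond the scatter) and a 4.0-fold lower number from compound 1 to compound 4 (0.61 log units; beyond the scatter). The last step exchanges only fluoro for amino on an aromatic carbon, so an added aromatic ring alone does not account for the difference: compound 1 has one too, yet cannot be separated from compound 3. Nothing available explains the change.

The compounds shown leave open whether a hydroxyl, a carboxylic acid or a dimethylamino group on that ring would match amino. They also leave open whether amino needs the ring at all, which a 2-aminoethyl chain in place of ethyl would test.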